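Replacing the Hydroxyphenyl Group: What to Expect for Compound 3

A few compounds are considered here, and "the series" means these few. Any claim that something is new, unique, unknown or untested is made for them only; others in the source may bear on it.

Compound 1, `COc1ccc(CN2C(=O)C(=O)c3cc(-c4cc(OC)cc(OC)c4)ccc32)cc1`: 1200 nM
Compound 2, `COc1ccc(CN2C(=O)C(=O)c3cc(-c4ccc(O)cc4)ccc32)cc1`: > 10000 nM

In a functional assay on HepG2 cells (Homo sapiens) for antiproliferative activity, read by MTT assay, with a stated time of 48 h (on this read-out lower numbers stand for stronger inhibition and higher numbers for weaker inhibition), compound 1 gives 1200 nM. Compound 2 gives > 10000 nM, which is a limit of this assay and not a number. Compound 2 therefore stands at the limit of > 10000 nM in this assay, at which 1 of the 2 values shown sits, so only a lower bound on its value is known. The single measured step, an at least 8.3-fold higher number from compound 1 to compound 2 (0.92 log units; beyond the scatter), shows that the 4-hydroxyphenyl group is tied to the weaker end of the two numbers shown.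

Compound 3, `COc1ccc(CN2C(=O)C(=O)c3cc(-c4ccc5ccccc5c4)ccc32)cc1`, differs from compound 2 by naphthalen-2-yl in place of 4-hydroxyphenyl on an aromatic carbon. This step removes the 4-hydroxyphenyl group that accompanies the limit value of compound 2, so a return toward the stronger end is expected; whether compound 3 reaches the level of compound 1 cannot be told from one step. Compound 3 is expected to give 3000 nM, in the range 800 nM to 15000 nM, an estimated change of an at least 3.3-fold lower number from compound 2 to compound 3 (0.52 log units; beyond the scatter).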

Compound 3, half-maximal inhibitory concentration: > 10000 nM
Compound 3: a limit, no number (the forecaster's own chance of this, stated with the estimate: 30%); middle value at least 3.3-fold (0.52 log units) from the limit.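

Losing the hydroxyl group does not restore activity at this position: naphthalen-2-yl, with no hydrogen-bond donor, leaves compound 3 at a limit of the assay and not a number in this assay, as compound 2 was. Against the 3,5-dimethoxyphenyl group, the change gives an at least 8.3-fold higher number from compound 1 to compound 3 (0.92 log units; beyond the scatter), so a larger all-carbon aromatic group does not stand in for that group here, and among these three compounds only compound 1 gives a number. The limit is now shared: the limit of > 10000 nM in this assay, at which 2 of the 3 values shown sit.

Going by these compounds, the step between compound 2 and compound 3 cannot be read, so their order remains unknown. Also open, on these data alone, is whether a phenyl ring carrying a single methoxy group, or an amine, would bring a measurable value at this position.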